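The source may hold more compounds than are shown below. What is called first, only, known or untested is meant among the compounds shown, and "the series" means these compounds.

Compound 1 `Cc1cc(C)c(CNC(=O)c2cccc(OC(C)C)c2Cl)c(=O)[nH]1` holds the lowest of the three values in a physicochemical assay for lipophilicity, at pH 7.4 (on this read-out higher numbers stand for higher lipophilicity and lower numbers for lower lipophilicity), giving 2. Compound 3 `Cc1cc(C)c(CN2CCc3c(C)cc(O[C@@H]4CCOC4)c(Cl)c3C2=O)c(=O)[nH]1` comes closest, with 2.1, a gap that lies within the scatter, while compound 2 `Cc1cc(C)c(CN2CCc3ccc(-c4c(C)noc4C)c(Cl)c3C2=O)c(=O)[nH]1` stands furthest away, at 2.6, a gap beyond the scatter. The untested compound 4 `Cc1cc(C)c(CNC(=O)c2cccc(OC(C)C)c2C)c(=O)[nH]1` differs from compound 1 in a single place: methyl in place of chloro on an aromatic carbon. For the measured compounds named here, no pair of measured compounds differs in just this way, so no measured step guides the expectation. In this assay only a small step is expected, probably a slight fall that stays within the scatter: a number 0.15 log units lower from compound 1 to compound 4 (within the scatter). Compound 4 is therefore estimated at 1.85, with a range from 1.45 to 2.25.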

Compound 4, distribution coefficient: 2.1
For compound 4 the middle estimate is 0.25 log units below the measured one; the measured number falls inside the stated range.
By their numbers in this assay, from the lowest: compounds 1, 3 and 4 (each within the scatter of the next); then compound 2.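

For the compounds shown here, the exchange of chloro for methyl is the first single-place change to be read directly at this position, ortho to an isopropoxy group. In this assay it gives a number 0.10 log units higher from compound 1 to compound 4 (within the scatter), so on this read-out the two groups cannot be told apart here. Nothing available explains this result. As far as these compounds go, whether the same exchange would behave alike on the cores of compound 2 and compound 3 remains open. So does whether a different group here, such as a methoxy group, an amine or a carboxylic acid, would move the number beyond the scatter.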